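A few compounds are considered here, and "the series" means these few. Any claim that something is new, unique, unknown or untested is made for them only; others in the source may bear on it.

Of the compounds shown here, three of one series have been tested in an assay on microsomes from liver for inhibition of sterol O-acyltransferase 1 (Rattus norvegicus); a higher number here means a weaker inhibitor, a lower number a stronger inhibitor. Compound 1 `C[C@@]1(O)CC(=O)OC(CSc2nc(-c3ccccc3)c(-c3ccccc3)[nH]2)C1` gives 170 nM in this assay. Compound 2 `COc1ccc(-c2nc(SCC3C[C@](C)(O)CC(=O)O3)[nH]c2-c2ccc(OC)cc2)cc1` gives 420 nM, and compound 3 `CC(C)c1ccc(-c2nc(SC[C@H]3C[C@@](C)(O)CC(=O)O3)[nH]c2-c2ccc(C(C)C)cc2)cc1.CC(C)c1ccc(-c2nc(SC[C@H]3C[C@](C)(O)CC(=O)O3)[nH]c2-c2ccc(C(C)C)cc2)cc1` gives 230 nM. Compound 1 thus stands at the low end of the three numbers; its gap to compound 2 is beyond the scatter, while its gap to compound 3 lies within the scatter, so no order between compound 1 and compound 3 can be read from these values.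

Compound 4 `c1ccc(CSc2nc(-c3ccccc3)c(-c3ccccc3)[nH]2)cc1` has not yet been measured. It differs from compound 1 in one place: a group of 6 heavy atoms (6 carbon; one six-membered aromatic ring of carbon only) in place of a group of 9 heavy atoms (6 carbon, 3 oxygen; one six-membered non-aromatic ring with 1 hetero atom), on a saturated chain carbon bound to a sulfur. The group that leaves carries the one hydrogen-bond donor and all three hydrogen-bond acceptors of that part of the molecule, and the phenyl that enters carries none; the shared core is unchanged.

Within the data shown here, no step between two measured compounds isolates this change, so the account can rest only on the three values above. A modest step toward a higher number in this assay is expected for compound 4, of the size a 2.6-fold higher number from compound 1 to compound 4 (0.42 log units; beyond the scatter), though a result within the scatter of compound 1 would not be surprising. The estimate for compound 4 is 450 nM, with a range from 120 nM to 2000 nM.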

Compound 4, half-maximal inhibitory concentration: 290 nM
Beside the measured number, compound 4's estimate is 1.6-fold (0.19 log units) above it; measured number inside the range.
By their numbers in this assay, from the lowest: compounds 1, 3, 4 and 2 (each within the scatter of the next, the first and the last beyond it).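

In this assay, phenyl in place of the six-membered non-aromatic ring group, on a saturated chain carbon bound to a sulfur, gives a 1.7-fold higher number from compound 1 to compound 4 (0.23 log units; within the scatter). Among these compounds, this is the first direct reading of this place. The hydrogen-bond donor, the hydrogen-bond acceptors and the defined stereocentre of the group that leaves can all be absent from this part of the molecule without a change that stands out from the scatter, so this pair gives no sign that the leaving group is needed for a value of this size. Nothing measured here explains why the two groups read alike.

A single replacement cannot tell whether other groups at this place, such as a cyclohexyl ring, a carboxylic acid or a longer chain, would also stay within the scatter of compound 1, or would move the number clearly in either direction. Going by these compounds, it also remains open whether the same change would read the same way on the cores of compound 2 and compound 3, since the step is known only on the core of compound 1.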